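Replacing 3-iodophenyl with 3,4-dichlorophenyl on the carbonyl carbon

The source may report more compounds than this note shows. Statements on the series, on what has been measured and on what is new or still open speak of the compounds shown alone.

In a functional assay on MCF7 cells (Homo sapiens) for inhibition, read by MTT assay (on this read-out higher numbers stand for weaker inhibition and lower numbers for stronger inhibition), compound 1 (`COc1cc2ncnc(Nc3ccc(NC(=O)c4ccccc4OC)cc3)c2cc1OC`) gives > 100000 nM, which is a limit of the assay and not a number. Among the measured compounds shown here, compound 2 (`COc1cc2ncnc(Nc3ccc(NC(=O)c4cccc(I)c4)cc3)c2cc1OC`) gives 30000 nM, the only actual number so far. Compound 3 (`COc1cc2ncnc(Nc3ccc(NC(=O)c4ccc(Cl)c(Cl)c4)cc3)c2cc1OC`) is still unmeasured and carries 3,4-dichlorophenyl in place of 3-iodophenyl on a carbonyl carbon. For the measured compounds named here, the only measured step is an at least 3.3-fold lower number from compound 1 to compound 2 (0.52 log units; beyond the scatter). That step brings in 3-iodophenyl in place of 2-methoxyphenyl, so it bears on the new change only indirectly, showing that the group on the carbonyl carbon can move the number. Going by the values given here, no measured step compares these two groups, so no step beyond the scatter is expected in this assay, in either direction. The estimated step is no change at the digits printed from compound 2 to compound 3 (within the scatter). For compound 3 the expected value is 30000 nM, with an estimated range of 10000 nM to 90000 nM.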

Compound 3, half-maximal inhibitory concentration: 25000 nM
Compound 3: the middle estimate sits 1.2-fold (0.08 log units) above what was measured, within the range that was stated.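

In this assay, the change of group on the carbonyl carbon gives a 1.2-fold lower number from compound 2 to compound 3 (0.08 log units; within the scatter), so 3,4-dichlorophenyl and 3-iodophenyl cannot be told apart at this position. The second new step, an at least 4.0-fold lower number from compound 1 to compound 3 (0.60 log units; beyond the scatter), shows that 3,4-dichlorophenyl, like 3-iodophenyl, gives a number clearly lower than 2-methoxyphenyl, so the earlier separation from compound 1 does not rest on 3-iodophenyl alone. This step has no upper bound on its size because compound 1 is reported only as a limit of the assay and not as a number: the limit of > 100000 nM in this assay, at which 1 of the 3 values shown sits.

Going by these compounds, what an unsubstituted phenyl, a carboxylic acid or a dimethylamino group would give at this position remains open. Also open, on these data alone, is whether any group on the carbonyl carbon can bring the number far below those of compound 2 and compound 3.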